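Solubility After Exchanging an Aromatic Substituent on a Shared Core

The compounds below may be only part of what the source reports. "The series", "measured", "known", "first", "only" and "open" are said of these compounds alone.

Measured compounds:
compound 1, `COc1cccc(CNCCCNc2ccnc3cc(-c4ccc(C(C)(C)C)cc4)ccc23)c1O`, in a physicochemical assay for solubility, with a stated time of 18 h, at pH 7.4; a higher number here means a more soluble compound, a lower number a less soluble compound: 32000 nM
compound 2, `CC(C)(C)c1ccc(-c2ccc3c(NCCCNCc4ccco4)ccnc3c2)cc1`: 32000 nM
compound 3, `c1ccc(Cc2ccc3c(NCCCNCc4ccco4)ccnc3c2)cc1`: 4200 nM

Compound 1 stands level with compound 2 at the digits shown, and the two together give the highest numbers of the three; the only other value, from compound 3, lies clearly lower, as the step of a 7.6-fold lower number from compound 2 to compound 3 (0.88 log units; beyond the scatter) shows. The step of no change at the digits printed from compound 1 to compound 2 (within the scatter), which exchanges the group on a saturated chain carbon bound to an amine nitrogen, stays within the scatter.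

Compound 4, `COc1cccc(CNCCCNc2ccnc3cc(Oc4cccc(N(C)C)c4)ccc23)c1O`, differs from compound 1 in one place: 3-(dimethylamino)phenoxy in place of 4-(tert-butyl)phenyl on an aromatic carbon. Among the measured compounds shown here, the step that bears on it is the one from compound 2 to compound 3, since that exchange also sits on an aromatic carbon of the shared core, and it was modest in size. The exchange leading to compound 4 is a different one, so the account rests on that single step only. Compound 4 is therefore expected to sit near compound 1, with the step of a 1.3-fold lower number from compound 1 to compound 4 (0.11 log units; within the scatter) estimated to remain within or close to the scatter; the estimated value for compound 4 is 25000 nM, in the range 8000 nM to 60000 nM.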

Compound 4, solubility: 14500 nM
Compound 4: middle estimate off by 1.7-fold (0.24 log units), on the high side, within the range that was stated.
By their numbers in this assay, from the lowest: compound 3; then compound 4; then compounds 1 and 2 (each within the scatter of the next).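

In this assay, placing 3-(dimethylamino)phenoxy in place of 4-(tert-butyl)phenyl on the aromatic carbon of the shared core gives a 2.2-fold lower number from compound 1 to compound 4 (0.34 log units; beyond the scatter), a modest step. Until now, this position had been seen to change only in a compound carrying the furan-2-yl group on the chain; this step shows a change beyond the scatter with the 2-hydroxy-3-methoxyphenyl group there, and with a entering group of the same heavy-atom count that brings nitrogen, oxygen and hydrogen-bond acceptors in place of an all-carbon group. Nothing at hand accounts for this step.

The compounds shown leave open which part of the entering group goes with the lower number, the phenoxy oxygen or the dimethylamino group; an unsubstituted phenoxy or a morpholine on the same aromatic carbon would help to separate the two. As far as these compounds go, it also remains open whether the step holds when the furan-2-yl group stands on the chain.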